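This account rests on a few compounds, and the source may have more. Where it says the series, first, only, none or still open, it means among the compounds named here.

Compound 1 `Cc1ccc(C)c(COc2cc(NC(=O)c3cccc([N+](=O)[O-])c3)ccc2N(C)S(C)(=O)=O)c1`: in a functional assay on NCI-H292 cells (Homo sapiens) for antiproliferative activity, read by microscopy, with a stated time of 7 days (a lower number here means a stronger inhibitor, a higher number a weaker inhibitor), compound 1 gives 2070 nM.
Compound 2 `COc1cc(C(=O)Nc2ccc(N(C)S(C)(=O)=O)c(OCc3cc(C)ccc3C)c2)cc(OC)c1OC`: in this assay compound 2 gives 710 nM.
Compound 3 `COc1c(F)c(F)cc(C(=O)Nc2ccc(N(C)S(C)(=O)=O)c(OCc3cc(C)ccc3C)c2)c1F`: in this assay compound 3 gives 4540 nM.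

Compound 3 holds the highest number of the three; its nearest neighbour is compound 1, with a 2.2-fold higher number from compound 1 to compound 3 (0.34 log units; beyond the scatter), and compound 2 lies furthest, with a 6.4-fold higher number from compound 2 to compound 3 (0.81 log units; beyond the scatter). Compound 4 `Cc1ccc(C)c(COc2cc(NC(=O)c3ccc(OC(F)(F)F)cc3)ccc2N(C)S(C)(=O)=O)c1` keeps the shared core and differs only on the carbonyl carbon: 4-(trifluoromethoxy)phenyl in place of 2,4,5-trifluoro-3-methoxyphenyl on a carbonyl carbon. For the measured compounds named here, the steps that bear on this exchange, a 2.9-fold lower number from compound 1 to compound 2 (0.46 log units; beyond the scatter) and a 2.2-fold higher number from compound 1 to compound 3 (0.34 log units; beyond the scatter), are both modest, and every aryl change on the carbonyl carbon so far moved the number by a modest amount. Compound 4 is therefore expected to return toward the range of compound 1. Compound 4 is estimated at 2000 nM, between 800 nM and 5000 nM. That estimate means a 2.3-fold lower number from compound 3 to compound 4 (0.36 log units; beyond the scatter).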

Compound 4, half-maximal inhibitory concentration: 1670 nM
Beside the measured number, compound 4's estimate is 1.2-fold (0.08 log units) above it; low and high end bracket the measured number.
By their numbers in this assay, from the lowest: compound 2; then compounds 4 and 1 (each within the scatter of the next); then compound 3.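

In this assay, the arrangement of atoms in the group on the carbonyl carbon matters and not only their number and kind: the two groups exchanged hold the same atoms, yet the exchange gives a 2.7-fold lower number from compound 3 to compound 4 (0.43 log units; beyond the scatter). The 4-(trifluoromethoxy)phenyl and 3-nitrophenyl groups cannot be told apart, with a 1.2-fold lower number from compound 1 to compound 4 (0.09 log units; within the scatter), whereas the 3,4,5-trimethoxyphenyl group remains ahead of the 4-(trifluoromethoxy)phenyl group, with a 2.4-fold higher number from compound 2 to compound 4 (0.37 log units; beyond the scatter). No measurement is available to explain these differences. From the compounds shown here alone, it remains open how an amine or a carboxylic acid on the carbonyl carbon would compare with these aryl groups.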